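A few compounds are considered here, and "the series" means these few. Any claim that something is new, unique, unknown or untested is made for them only; others in the source may bear on it.

Compound 1 `CS(=O)(=O)Nc1ccc([N+](=O)[O-])cc1OCc1ccc(F)cc1` gives 580 nM in an assay on SK-BR-3 cells for inhibition of Aromatase (Homo sapiens) (a higher number here means a weaker inhibitor, a lower number a stronger inhibitor), the higher of the two numbers on record, though the gap to compound 2 `CN(c1ccc([N+](=O)[O-])cc1OCc1ccc(Br)cc1)S(C)(=O)=O`, which gives 330 nM, lies within the scatter, so the pair stands on one level. Compound 3 `CS(=O)(=O)Nc1ccc([N+](=O)[O-])cc1OCc1ccc(-c2ccccc2)cc1` differs from compound 1 by phenyl in place of fluoro on an aromatic carbon, para to a large group. Within the data shown here, no measured pair carries this change, and compound 2 differs from compound 1 at two places, so nothing can be read from it. The step is expected to stay within the scatter, a 1.3-fold lower number from compound 1 to compound 3 (0.11 log units; within the scatter). For compound 3 the estimate is 450 nM, between 120 nM and 1800 nM.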

Compound 3, half-maximal inhibitory concentration: 850 nM
The estimate for compound 3 lay 1.9-fold (0.28 log units) below the measured number, and the stated range covers the measured number.
By their numbers in this assay, from the lowest: compounds 2, 1 and 3 (each within the scatter of the next, the first and the last beyond it).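

Phenyl in place of fluoro on an aromatic carbon, para to a large group, gives a 1.5-fold higher number from compound 1 to compound 3 (0.17 log units; within the scatter) in this assay. This position therefore holds phenyl as well as fluoro, with no shift beyond the scatter, so compound 1 and compound 3 stand on one level. No measurement at hand bears on the origin of this result.

From the compounds shown here alone, whether an amine, a carboxylic acid or a longer chain at this position would move the number beyond the scatter stays open. Compound 2 differs from compound 1 at two places, so neither change can be read alone.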